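The compounds below may be only part of what the source reports. "The series", "measured", "known", "first", "only" and "open" are said of these compounds alone.

Measured in a functional assay on MT4 cells (Homo sapiens) for cytotoxicity, read by CellTiter-Glo, with a stated time of 5 days (a lower number here means that less compound is needed, a higher number that more compound is needed for the effect), are three compounds:
Compound 1 `Cc1ccc(-c2c(C)noc2C)cc1S(=O)(=O)NC1CCCC1` gives 1590 nM
Compound 2 `Cc1noc(C)c1-c1cc(-c2c(C3CC3)n[nH]c2C)c2[nH]c(C3CC3)nc2c1` gives 8 nM
Compound 3 `CC(=O)NCc1onc(C)c1-c1ccc(C)c(S(=O)(=O)NC2CCCC2)c1` gives 4920 nM

Compound 1 holds the second highest of these three numbers, with compound 3 nearest above it and compound 2 far below. Compound 4 `Cc1ccc(-c2cnoc2)cc1S(=O)(=O)NC1CCCC1` carries 1,2-oxazol-4-yl in place of 3,5-dimethyl-1,2-oxazol-4-yl on an aromatic carbon, para to a methyl group: 1,2-oxazol-4-yl in place of 3,5-dimethyl-1,2-oxazol-4-yl on an aromatic carbon. Among the compounds with values here, only one measured step alters this group, a 3.1-fold higher number from compound 1 to compound 3 (0.49 log units; beyond the scatter), a modest change beyond the scatter, made by acetamido in place of hydrogen on a saturated chain carbon. It is a different change, so it offers only weak guidance. A modest step to a higher number is expected, estimated as a 2.5-fold higher number from compound 1 to compound 4 (0.40 log units; beyond the scatter). The expected value for compound 4 is 4000 nM within an estimated range of 1500 nM to 12000 nM.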

Compound 4, half-maximal effective concentration: 43200 nM
The estimate for compound 4 lay 11-fold (1.03 log units) below the measured number; measured number outside the range, above it.
By their numbers in this assay, from the lowest: compound 2; then compound 1; then compound 3; then compound 4.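

Going from 3,5-dimethyl-1,2-oxazol-4-yl to 1,2-oxazol-4-yl on this aromatic carbon, para to a methyl group, gives a 27-fold higher number from compound 1 to compound 4 (1.43 log units; beyond the scatter) in this assay. This step is much larger than a 3.1-fold higher number from compound 1 to compound 3 (0.49 log units; beyond the scatter), showing that the number responds strongly at this position to a change of only two heavy atoms. No measurement shown here accounts for the rise. Going by these compounds, it remains open whether one methyl group alone would restore the number of compound 1 or whether both are needed. Also open, on these data alone, is how an ethyl group or an amine would behave on the same ring.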